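The source may report more compounds than this note shows. Statements on the series, on what has been measured and on what is new or still open speak of the compounds shown alone.

Measured so far:
compound 1, `Cn1c(=O)c(S(=O)(=O)c2ccc(F)cc2F)cc2cnc(Nc3ccc4occc4c3)nc21`: 15000 nM
compound 2, `Cn1c(=O)c(C(=O)Nc2ccc(F)cc2F)cc2cnc(Nc3ccc4[nH]ccc4c3)nc21`: 5000 nM

Both were tested in a functional assay on DU-145 cells (Homo sapiens) for inhibition, read by trypan blue exclusion, with a stated time of 72 h; a lower number here means a stronger inhibitor, a higher number a weaker inhibitor. Compound 1 gives 15000 nM there, and compound 2 gives 5000 nM; compound 1 thus stands highest of the two numbers, with compound 2 giving the lower one, a gap beyond the usual scatter. Among the measured compounds shown here, the two compounds differ in more than one place, so no single step between them is drawn.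

Compound 3, `Cn1c(=O)c(S(=O)(=O)c2ccc(F)cc2F)cc2cnc(Nc3cnc4[nH]ccc4c3)nc21`, has not been measured in this assay. It differs from compound 1 as follows: a group of 9 heavy atoms (7 carbon, 2 nitrogen; one five-membered aromatic ring with 1 hetero atom, one six-membered aromatic ring with 1 hetero atom) in place of a group of 9 heavy atoms (8 carbon, 1 oxygen; one five-membered aromatic ring with 1 hetero atom, one six-membered aromatic ring of carbon only), on a nitrogen on an aromatic ring The entering group carries one hydrogen-bond donor, which the leaving 1-benzofuran-5-yl group lacks. Compound 2 also carries a hydrogen-bond donor on that nitrogen and gives 5000 nM, though it differs elsewhere as well, so that comparison is loose. Compound 3 is therefore expected to give 6000 nM in this assay, within a range of 2000 nM to 18000 nM. The expected step of a 2.5-fold lower number from compound 1 to compound 3 (0.40 log units; beyond the scatter) is modest and towards a lower number, near the edge of the scatter.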

Compound 3, half-maximal inhibitory concentration: 750 nM
Estimate against measurement, compound 3: 8.0-fold (0.90 log units) above; measured number outside the range, below it.
By their numbers in this assay, from the lowest: compound 3; then compound 2; then compound 1.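

In this assay, replacing the 1-benzofuran-5-yl group on a nitrogen on an aromatic ring gives a 20-fold lower number from compound 1 to compound 3 (1.30 log units; beyond the scatter), a large step. Because everything else stays the same, this pair shows that the number responds strongly to the group at this position alone, which compound 1 and compound 2 could not show, as they differ in more than one place. Nothing on hand explains the size of the step.

The entering group differs in two ways at once, gaining a hydrogen-bond donor and a nitrogen in its six-membered aromatic ring, and the compounds shown do not separate these two differences. They also leave open how a simpler group at this position, such as a phenyl ring carrying an amine, would compare.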